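The source may report more compounds than this note shows. Statements on the series, on what has been measured and on what is new or still open speak of the compounds shown alone.

Measured compounds:
compound 1 `COc1ccc(CCCN2CCC(COC(c3ccc(Cl)cc3)c3ccc(Cl)cc3)CC2)cc1` — in a functional assay on cells (T-cell line, Homo sapiens) for inhibition (a lower number here means a stronger inhibitor, a higher number a weaker inhibitor), compound 1 gives 1100 nM
compound 2 `COc1ccc(CCCN2CCC(CCC(c3ccccc3)c3ccccc3)CC2)cc1` — compound 2 gives 200 nM
compound 3 `Cc1ccc(CCCN2CCC(COC(c3ccccc3)c3ccccc3)CC2)cc1` — compound 3 gives 200 nM

In this assay compound 3 stands level with compound 2 at the digits shown, and the two together hold the lowest numbers of the three. Compound 1 is the furthest from compound 3: its number is higher, and that gap lies beyond the scatter. Compounds 2 and 3 differ in more than one place, so only their two values can be set side by side, and those show no change beyond the scatter.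

Compound 4 `CCCCCCCCCN1CCC(COC(c2ccccc2)c2ccccc2)CC1` has not yet been measured in this assay. Against compound 3 the difference is hexyl in place of 4-methylphenyl on a saturated chain carbon, three bonds along the chain from an amine nitrogen in a ring. Cut one bond further out, the same difference reads 3-(4-methylphenyl)propyl to nonyl.

For the measured compounds named here, no measured pair makes a change of this kind, so there is no step to lean on. All three measured compounds carry a six-membered aromatic ring at this place; compound 4 would be the first without one. The step of a 3.0-fold higher number from compound 3 to compound 4 (0.48 log units; beyond the scatter) is an estimate, and a moderate move toward a higher number is expected, though a result within the scatter cannot be ruled out. Compound 4 is expected to give about 600 nM in this assay, with a range from 150 nM to 2500 nM.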

Compound 4, half-maximal inhibitory concentration: 700 nM
Beside the measured number, compound 4's estimate is 1.2-fold (0.07 log units) below it; the measured number falls inside the stated range.
By their numbers in this assay, from the lowest: compounds 2 and 3 (each within the scatter of the next); then compounds 4 and 1 (each within the scatter of the next).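

In this assay, for the compounds shown here, hexyl in place of 4-methylphenyl, on a saturated chain carbon three bonds along the chain from an amine nitrogen in a ring, gives a 3.5-fold higher number from compound 3 to compound 4 (0.54 log units; beyond the scatter) and gives the first read on a change at this position. The step lies beyond the scatter, so the swap does register, yet compound 4, with no ring at this place, still gives 700 nM and remains an inhibitor in this assay, so a six-membered aromatic ring is not required here. No data shown account for the step.

Loss of the ring and the change in the chain cannot be told apart from this single pair. A cyclohexyl group at the same place, or a shorter or longer chain ending in a carboxylic acid or an amine, would show how far this position tolerates other groups.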